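Ester variants of a shared quinone core: isomeric hydroxy acid chain

The source may report more compounds than this note shows. Statements on the series, on what has been measured and on what is new or still open speak of the compounds shown alone.

Compound 3 `CC(C)=CC[C@@H](OC(=O)CC(C)(O)C(C)C)C1=CC(=O)c2c(O)ccc(O)c2C1=O` gives 27700 nM in a functional assay on HeLa cells (Homo sapiens) for cytotoxicity, read by MTT assay (on this read-out higher numbers stand for weaker inhibition and lower numbers for stronger inhibition), the second highest of the three numbers; compound 2 `CC(=O)OCCC(=O)O[C@H](CC=C(C)C)C1=CC(=O)c2c(O)ccc(O)c2C1=O` gives 17300 nM and compound 1 `CC(C)=CC[C@@H](OC(=O)c1ccco1)C1=CC(=O)c2c(O)ccc(O)c2C1=O` gives 80300 nM. Compound 4 `CCC(O)(CC)CC(=O)O[C@H](CC=C(C)C)C1=CC(=O)c2c(O)ccc(O)c2C1=O` differs from compound 3 as follows: 1-ethyl-1-hydroxypropyl in place of 1-hydroxy-1,2-dimethylpropyl on a saturated chain carbon bound to a carbonyl carbon. Among the measured compounds shown here, the one step that bears on it is the change at the same saturated chain carbon, a 1.6-fold higher number from compound 2 to compound 3 (0.20 log units; within the scatter). Larger steps arose only when the furan-2-yl group was exchanged, as in a 4.6-fold lower number from compound 1 to compound 2 (0.67 log units; beyond the scatter) and a 2.9-fold lower number from compound 1 to compound 3 (0.46 log units; beyond the scatter). A rearrangement of the same atoms on the chain is therefore expected to give no step beyond the scatter, a 1.0-fold higher number from compound 3 to compound 4 (0.00 log units; within the scatter). Compound 4 is estimated at 28000 nM, within 12000 nM to 60000 nM.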

Compound 4, half-maximal inhibitory concentration: 52000 nM
Compound 4: middle estimate off by 1.9-fold (0.27 log units), on the low side; low and high end bracket the measured number.
By their numbers in this assay, from the lowest: compounds 2, 3, 4 and 1 (each within the scatter of the next, the first and the last beyond it).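

In this assay, the exchange of 1-hydroxy-1,2-dimethylpropyl for the isomeric 1-ethyl-1-hydroxypropyl on this saturated chain carbon stays within the scatter (a 1.9-fold higher number from compound 3 to compound 4 (0.27 log units; within the scatter)). Among the compounds shown here, at the same carbon, 1-ethyl-1-hydroxypropyl in place of acetoxymethyl goes beyond the scatter (a 3.0-fold higher number from compound 2 to compound 4 (0.48 log units; beyond the scatter)), and 2-ethyl-2-hydroxybutyl is the first replacement of furan-2-yl on the carbonyl carbon that stays within it (a 1.5-fold lower number from compound 1 to compound 4 (0.19 log units; within the scatter)). No measurement at hand accounts for these differences.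

Still open, on these data alone, is how an amine, a carboxylic acid or a longer chain on this carbon would read out.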